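The source may report more compounds than this note shows. Statements on the series, on what has been measured and on what is new or still open speak of the compounds shown alone.

Measured so far:
compound 1, `COc1cc(C)c(S(=O)(=O)N(C)CCOCC(=O)N(C)Cc2ccc(C3=NCCN3)cc2)c(C)c1`, gives 8.2 in a functional assay for antagonist activity at B1 bradykinin receptor (Mus musculus), using Schild analysis, with a stated time of 30 min; on this read-out lower numbers stand for lower potency and higher numbers for higher potency (the scale is a negative logarithm)
compound 2, `Cc1c(Cl)cccc1S(=O)(=O)N(C)CCOCC(=O)N(C)Cc1ccc(C2=NCCN2)cc1`, gives "not determined" (no result reported) in this assay

Compound 2 stands nowhere on the numbers shown: in this assay compound 2 has no reported value, so no step from it can be reckoned. Compound 3, `CN(Cc1ccc(C2=NCCN2)cc1)C(=O)COCCN(C)S(=O)(=O)c1c(Cl)cccc1Cl`, differs from compound 2 by 2,6-dichlorophenyl in place of 3-chloro-2-methylphenyl on a sulfonyl sulfur. With compound 2 unmeasured, no direction can be assigned to this step in this assay, and nothing beyond the scatter is assumed. The only anchor in the series is compound 1, which gives 8.2 in this assay. Compound 3 is expected near that, estimated at 8 with a range of 7.2 to 8.7.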

Compound 3, negative logarithm of the antagonist equilibrium constant: 7.2
Estimate against measurement, compound 3: 0.80 log units above; the range from low to high includes it.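

In this assay the group on the sulfonyl sulfur is not neutral to change: 2,6-dichlorophenyl in place of 4-methoxy-2,6-dimethylphenyl gives a number 1.00 log units lower from compound 1 to compound 3 (beyond the scatter). The step between compound 2 and compound 3 cannot be read, so 3-chloro-2-methylphenyl remains unplaced at this position. No measurement shown accounts for the loss.

The compounds shown leave open how the step divides between losing the methoxy group and exchanging methyl for chlorine. Also open, from the compounds shown here alone, is how an unsubstituted phenyl or a pyridine on the sulfonyl sulfur would compare.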